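The source may hold more compounds than are shown below. What is called first, only, known or untested is meant among the compounds shown, and "the series" means these compounds.

Measured compounds:
Compound 1, `CCCc1c(COc2ccc(C(=O)CCc3nnn[nH]3)cc2)ccc(C(C)=O)c1O`: 7.09
Compound 2, `CCCc1c(COc2ccc(C(=O)C(C)(C)Cc3nnn[nH]3)cc2)ccc(C(C)=O)c1O`: 6.93
Compound 3, `CCc1c(COc2ccc(C(=O)CC(C)(C)Cc3nnn[nH]3)cc2)ccc(C(C)=O)c1O`: 8.09

All three were tested in a functional assay on ileum (Cavia porcellus) with cysteinyl leukotriene receptor (Homo sapiens) as the target; on this read-out higher numbers stand for higher potency (the scale is a negative logarithm) and lower numbers for lower potency. Compound 3 holds the highest of the three numbers: compound 1 lies a step below it that is beyond the scatter, and compound 2 lies further below still, also beyond the scatter. Compound 1 and compound 2 differ from each other only in the chain carrying the tetrazole, and a number 0.16 log units lower from compound 1 to compound 2 (within the scatter) shows that this exchange made no difference beyond the scatter.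

The unmeasured compound 4, `CCCc1c(COc2ccc(C(=O)CC(C)(C)Cc3nnn[nH]3)cc2)ccc(C(C)=O)c1O`, keeps the whole side chain of compound 3 and alters only the core: methyl in place of hydrogen on a saturated chain carbon, two bonds along the chain from an aromatic carbon. Going by the values given here, none of the measured steps touches this position, so the only guidance is that compound 1 and compound 2, which both carry the longer chain, lie well below compound 3, while compound 3 carries the shorter chain together with a different tetrazole-bearing chain. Those two effects cannot be separated on the numbers at hand. The lengthening is therefore expected to move this assay little; the expected step is a number 0.14 log units lower from compound 3 to compound 4 (within the scatter). Compound 4 is estimated at 7.95, within a range from 7.35 to 8.55.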

Compound 4, negative logarithm of the antagonist equilibrium constant: 7.86
For compound 4 the middle estimate is 0.09 log units above the measured one; low and high end bracket the measured number.
By their numbers in this assay, from the lowest: compounds 2 and 1 (each within the scatter of the next); then compounds 4 and 3 (each within the scatter of the next).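

In this assay, going from ethyl to propyl on the core while the 2-((1H-tetrazol-5-yl)methyl)-2-methylpropyl chain stays fixed gives a number 0.23 log units lower from compound 3 to compound 4 (within the scatter), so this position accepts the added methyl on this chain without a change beyond the scatter. With propyl held constant on the core, altering the tetrazole-bearing chain alone gives a number 0.93 log units higher from compound 2 to compound 4 (beyond the scatter), and another such exchange gives a number 0.77 log units higher from compound 1 to compound 4 (beyond the scatter), which places the gap that could not be divided earlier in the chain rather than in the ethyl to propyl change. Nothing among the available measurements offers an explanation for any of these steps.

The compounds shown leave open whether a butyl chain at this position, or a carboxylic acid in place of the tetrazole, would keep the number in this assay at this level. Ethyl appears only together with the chain of compound 3, so it also remains open whether the ethyl to propyl change would be equally small alongside the other two tetrazole-bearing chains.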